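Swapping the aryl group: expected toxicity on Vero cells

A few compounds are considered here, and "the series" means these few. Any claim that something is new, unique, unknown or untested is made for them only; others in the source may bear on it.

Compound 3 `CC1=C(C(=O)Nc2ccccc2Cl)C(c2ccc(Br)cc2)NC(=O)N1` belongs to a small set measured in an ADME assay on Vero cells (Chlorocebus sabaeus) for cytotoxicity, read by XTT assay, with a stated time of 72 h; on this read-out higher numbers stand for lower toxicity in this test and lower numbers for higher toxicity in this test. For compound 3 the result is a limit of the assay rather than a number, > 100000 nM. Compound 1 `CC1=C(C(=O)NC2CCCCC2)C(c2ccccc2)NC(=O)N1` likewise reaches only a limit in this assay, > 100000 nM. Compound 2 `CC1=C(C(=O)Nc2ccccc2Cl)C(c2ccccc2Cl)NC(=O)N1` is recorded in this assay as "non-toxic" (no number reported), with no number attached. Within the data shown here, compound 3 therefore stands where its companions stand: the limit of > 100000 nM in this assay, at which 2 of the 3 values shown sit, and the remaining entry carries no number at all, so no compound in the set shows measurable toxicity.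

Compound 4 `COc1cccc(C2NC(=O)NC(C)=C2C(=O)Nc2ccccc2Cl)c1` differs from compound 3 in one place: 3-methoxyphenyl in place of 4-bromophenyl on a saturated ring carbon. Among the measured compounds shown here, no step between two measured compounds is available that would show what such a change does in this read-out, and nothing among the three measured compounds points towards toxicity. In this assay the expected step is none beyond the scatter, a step that the limit leaves unreadable from compound 3 to compound 4. Compound 4 is expected to give 120000 nM in this assay, with a range from 50000 nM to 300000 nM, and most probably the assay will again report only a limit for compound 4.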

Compound 4, half-maximal cytotoxic concentration: > 100000 nM
Compound 4: only a limit was reported; the forecaster's own chance of this, stated with the estimate: 80%; the middle value is on the limit's open side.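

Among these compounds, compound 3 and compound 4 both end at a limit in this assay rather than at a number, so no step from compound 3 to compound 4 can be read. The compounds shown leave open whether any of them reaches a measurable toxic concentration in this test, and how 3-methoxyphenyl and 4-bromophenyl compare there.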